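Cyclobutyl for cyclopropyl on a thiophene-bearing core

A few compounds are considered here, and "the series" means these few. Any claim that something is new, unique, unknown or untested is made for them only; others in the source may bear on it.

Compound 1, `CC1=C(C(=O)OCC2CC2)C(c2ccco2)NC(=O)N1`: in an assay on membranes from CHO cells for displacement of a labelled ligand from adenosine receptor A1 (Homo sapiens), read by scintillation counting, with a stated time of 60 min, tested at 1 uM (on this read-out higher numbers stand for more inhibition at the one concentration tested (going by the name of the read-out) and lower numbers for less inhibition), compound 1 gives 29%.
Compound 2, `CC1=C(C(=O)OCC2CCC2)C(c2ccco2)NC(=O)N1`: in this assay compound 2 gives 42%.
Compound 3, `CC1=C(C(=O)OCC2CC2)C(c2cccs2)NC(=O)N1`: in this assay compound 3 gives 23%.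

Compound 1 and compound 2 share one core and differ in a single place: cyclobutyl in place of cyclopropyl on a saturated chain carbon bound to an oxygen next to a carbonyl group. This change is measured, and it made a number 13 percentage points higher from compound 1 to compound 2 (beyond the scatter).

Compound 3 carries a different core than compound 1, and the difference between the two cores is thiophen-2-yl in place of furan-2-yl on a saturated ring carbon. That change gave a number 6 percentage points lower from compound 1 to compound 3 (within the scatter), so compound 1 and compound 3 cannot be told apart on this read-out.

Compound 4, `CC1=C(C(=O)OCC2CCC2)C(c2cccs2)NC(=O)N1`, has not yet been measured. It stands to compound 3 as compound 2 stands to compound 1: cyclobutyl in place of cyclopropyl on a saturated chain carbon bound to an oxygen next to a carbonyl group. The place of the change is the same in both pairs, word for word, so the change on the core of compound 3 is the same change that was measured on the core of compound 1.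

Among the compounds with values here, with only one earlier example of this change, the expectation rests on it alone: compound 4 is expected to show a number 13 percentage points higher from compound 3 to compound 4 (beyond the scatter) in this assay, about the size of the step seen in a number 13 percentage points higher from compound 1 to compound 2 (beyond the scatter), because compound 3 starts from 23%. On that basis compound 4 is estimated at 36%, with a likely range from 24% to 48%.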

Compound 4, a percentage reported as inhibition, at one concentration (the size of the read-out at that concentration, not a potency): 39%
Compound 4: middle estimate off by 3 percentage points, on the low side; the range from low to high includes it.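

In this assay, cyclobutyl in place of cyclopropyl gave a number 16 percentage points higher from compound 3 to compound 4 (beyond the scatter), and the change carried over from the core of compound 1 to the core of compound 3 with no step size that can be told apart: the same change on two cores in this assay, a number 13 percentage points higher (beyond the scatter) from compound 1 to compound 2 and a number 16 percentage points higher (beyond the scatter) from compound 3 to compound 4, 3 percentage points apart, within the scatter of two such steps

The exchange on the saturated ring carbon, thiophen-2-yl in place of furan-2-yl, gave a number 3 percentage points lower from compound 2 to compound 4 (within the scatter), and it reads alike with either ester side chain: the same change on two cores in this assay, a number 6 percentage points lower (within the scatter) from compound 1 to compound 3 and a number 3 percentage points lower (within the scatter) from compound 2 to compound 4, 3 percentage points apart, within the scatter of two such steps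

Together these steps show that, within these four compounds, the two changes behaved independently of each other, but they come from a single pair of cores and a single tested concentration, so they do not show that the step would hold on a core that differs in any other way, nor do they give a potency or say why the step occurs.

The compounds shown leave open whether a longer chain in place of cyclobutyl on the saturated chain carbon would extend the step or end it. They also leave open whether the step survives on a core carrying an amine or a carboxylic acid on the saturated ring carbon in place of thiophen-2-yl or furan-2-yl.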